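The source may hold more compounds than are shown below. What is called first, only, known or untested is meant among the compounds shown, and "the series" means these compounds.

Compound 1 `CCCC[C@H]1CCCC[C@H](C)[C@@H](O[C@H]2OC[C@@H](O)[C@@H](O)[C@H]2O)c2cc(O)c(c(O)c2)[C@@H](CCCC)CCCC[C@H](C)[C@@H](O[C@@H]2OC[C@@H](O)[C@@H](O)[C@H]2O)c2cc(O)c1c(O)c2` and compound 2 `CCCC[C@H]1CCCC[C@H](C)Cc2cc(O)c(c(O)c2)[C@@H](CCCC)CCCC[C@H](C)[C@@H](O[C@@H]2OC[C@@H](O)[C@@H](O)[C@H]2O)c2cc(O)c1c(O)c2` differ at a single saturated ring carbon of the shared core. In a functional assay on MDA-MB-231 cells (Homo sapiens) for antiproliferative activity (on this read-out lower numbers stand for stronger inhibition and higher numbers for weaker inhibition), compound 1 gives 600 nM, and in this assay compound 2 gives 600 nM. Among the measured compounds shown here, the one measured step, no change at the digits printed from compound 1 to compound 2 (within the scatter), exchanges a large ring-bearing group at that carbon for a hydrogen atom and leaves the read-out where it was, so compound 2 stands level with compound 1 and the position appears to accept a substantial change without a shift beyond the scatter.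

Compound 3 `CCCC[C@H]1CCCC[C@H](C)[C@@H](OC(C)=O)c2cc(O)c(c(O)c2)[C@@H](CCCC)CCCC[C@H](C)[C@@H](O[C@@H]2OC[C@@H](O)[C@@H](O)[C@H]2O)c2cc(O)c1c(O)c2` is the next compound at this same position. Relative to compound 2 it carries acetoxy in place of hydrogen on a saturated ring carbon. For the measured compounds named here, the only step that bears on this change is the one from compound 1 to compound 2, which was flat, and an acetoxy group is far smaller than the group removed there. On that basis compound 3 is expected to show essentially no movement beyond the scatter, a step of no change at the digits printed from compound 2 to compound 3 (within the scatter). The estimate for compound 3 in this assay is therefore 600 nM, with a range from 300 nM to 1300 nM.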

Compound 3, half-maximal inhibitory concentration: 800 nM
Beside the measured number, compound 3's estimate is 1.3-fold (0.12 log units) below it, and the stated range covers the measured number.
By their numbers in this assay, from the lowest: compounds 1, 2 and 3 (each within the scatter of the next).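

In this assay, putting an acetoxy group on this saturated ring carbon gives a 1.3-fold higher number from compound 2 to compound 3 (0.12 log units; within the scatter), so a small group without a ring sits here as readily as a hydrogen atom. Set against the large ring-bearing group, the same acetoxy compound shows a 1.3-fold higher number from compound 1 to compound 3 (0.12 log units; within the scatter), which puts all three occupants of this position, hydrogen, acetoxy and the ring-bearing group, within the scatter of one another, and the flat first step is no longer a single observation. Nothing measured here explains why the read-out stays flat across these three groups.

Still open, as far as these compounds go, is whether the flat read-out extends beyond these occupants, for example to a free hydroxy group, an amine or a carboxylic acid at this carbon, or to a longer chain in place of the acetoxy group. Also open, from the compounds shown here alone, is whether the large ring-bearing group that all three compounds keep elsewhere on the shared core can be changed as freely, since every comparison so far leaves it untouched.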